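The compounds below may be only part of what the source reports. "The series", "measured", "known", "first", "only" and "open" are said of these compounds alone.

Measured so far:
compound 1, `CCCCCn1c(=O)n(CCCCN2CCN(c3ccc(F)cc3)CC2)c2ccccc21`: 2270 nM
compound 2, `CC(=O)c1ccc2c(c1)n(C)c(=O)n2CCCCN1CCN(c2ccc(F)cc2)CC1`: 72.3 nM

In an assay on membranes from brain for displacement of a labelled ligand from Sigma non-opioid intracellular receptor 1 (Rattus norvegicus), read by radioligand binding, with a stated time of 120 min (a higher number here means a weaker inhibitor, a lower number a stronger inhibitor), compound 2 gives 72.3 nM, the lowest of the two numbers; the nearest, compound 1, gives 2270 nM, a gap well beyond the scatter. Going by the values given here, compounds 1 and 2 differ in two places at once, so no single step between them can be set apart; the two values only show that both changes together move the number a long way.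

Compound 3, `CCCCCn1c(=O)n(CCCCN2CCN(c3ccc(F)cc3)CC2)c2ccc(C(C)=O)cc21`, is yet to be measured in this assay. It is compound 2 with butyl in place of hydrogen on a saturated chain carbon bound to an aromatic nitrogen. Compound 3 thus carries the chain of compound 1 together with the acetyl group of compound 2. Among the compounds with values here, with no single-change step on record the direction is uncertain; the step expected in this assay for compound 3 is a 2.8-fold higher number from compound 2 to compound 3 (0.44 log units; beyond the scatter), a moderate weakening. Compound 3 is expected to give 200 nM, with a range from 50 nM to 800 nM.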

Compound 3, inhibition constant: 299 nM
For compound 3 the middle estimate is 1.5-fold (0.17 log units) below the measured one; the measured number falls inside the stated range.
By their numbers in this assay, from the lowest: compound 2; then compound 3; then compound 1.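

Going by these compounds alone, compound 3 lets the two changes be read separately for the first time in this assay. Butyl in place of hydrogen on a saturated chain carbon bound to an aromatic nitrogen, which also reads as methyl to pentyl, weakens binding with the acetyl group present, giving a 4.1-fold higher number from compound 2 to compound 3 (0.62 log units; beyond the scatter), while acetyl in place of hydrogen on an aromatic carbon strengthens binding with the pentyl chain present, giving a 7.6-fold lower number from compound 1 to compound 3 (0.88 log units; beyond the scatter). No measurement bears on the cause of either step.

On these data alone, each change rests on a single pair, so it remains open whether the butyl step would hold without the acetyl group, or the acetyl step with methyl in place of pentyl. Also open, as far as these compounds go, is how an ethyl or propyl chain, or a primary amine or carboxylic acid in place of acetyl, would read here.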